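Methoxy for trifluoromethyl on a benzoylguanidine

A few compounds are considered here, and "the series" means these few. Any claim that something is new, unique, unknown or untested is made for them only; others in the source may bear on it.

Measured so far in a functional assay for inhibition of sodium/hydrogen exchanger (Oryctolagus cuniculus); on this read-out lower numbers stand for stronger inhibition and higher numbers for weaker inhibition:
- compound 1 `CS(=O)(=O)c1cc(C(=O)N=C(N)N)ccc1-n1cccn1` gives 160 nM
- compound 2 `CS(=O)(=O)c1cc(C(=O)N=C(N)N)ccc1C(F)(F)F` gives 140 nM

Compound 2 has the lowest number of the two, but its neighbour compound 1 sits within the scatter of it: a 1.1-fold lower number from compound 1 to compound 2 (0.06 log units; within the scatter). The two numbers therefore cannot be told apart.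

Compound 3 `COc1ccc(C(=O)N=C(N)N)cc1S(C)(=O)=O` has not been measured. It differs from compound 2 in one place: methoxy in place of trifluoromethyl on an aromatic carbon. Among the measured compounds shown here, the only step known on this position, trifluoromethyl in place of 1H-pyrazol-1-yl, changed nothing beyond the scatter, so the two groups tried so far give the same result. Nothing is known about methoxy here, and a group with one hydrogen-bond acceptor has not been tried. The expectation is a small step, if any, with the number for compound 3 expected to stay near those of compound 1 and compound 2, so that a 1.8-fold higher number from compound 2 to compound 3 (0.25 log units; within the scatter) is estimated. Compound 3 is thus expected to give about 250 nM in this assay, within a range from 90 nM to 800 nM.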

Compound 3, half-maximal inhibitory concentration: 270 nM
The estimate for compound 3 lay 1.1-fold (0.03 log units) below the measured number, within the range that was stated.
By their numbers in this assay, from the lowest: compounds 2, 1 and 3 (each within the scatter of the next).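

With a 1.9-fold higher number from compound 2 to compound 3 (0.29 log units; within the scatter) and a 1.7-fold higher number from compound 1 to compound 3 (0.23 log units; within the scatter) methoxy cannot be told apart from trifluoromethyl or 1H-pyrazol-1-yl in this assay at this position, ortho to a methylsulfonyl group. The exchange of trifluoromethyl, with 4 heavy atoms and 0 hydrogen-bond acceptors, for methoxy, with 2 heavy atoms and 1 hydrogen-bond acceptor, therefore leaves the number within the scatter, so these differences in size and acceptor count produce no readable step in this set. No measured evidence is available to explain why these three groups give numbers that cannot be separated.

Still open, going by these compounds, is whether any group at this position can move the number beyond the scatter. A plain hydrogen, an amine, a carboxylic acid or a longer chain such as butoxy would each put that question to a test.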